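A few compounds are considered here, and "the series" means these few. Any claim that something is new, unique, unknown or untested is made for them only; others in the source may bear on it.

Measured in a functional assay on MOLT-4 cells (Homo sapiens); a higher number here means a weaker inhibitor, a lower number a stronger inhibitor:
- compound 1 `CCOc1ncnc2c1ncn2C[C@@H]1C[C@H](CO)c2ccccc21`: 24 ug/mL
- compound 2 `OC[C@H]1C[C@@H](Cn2cnc3c(Cl)ncnc32)c2ccccc21`: 24 ug/mL
- compound 3 `Cn1ncc2c1[C@H](Cn1cnc3c(Cl)nc(N)nc31)C[C@@H]2CO`: 3.2 ug/mL

Compound 2 stands level with compound 1, and together they hold the highest of the three numbers. Compound 3 has a lower number, beyond the scatter, but it differs from compound 2 in more than one place and offers no clean comparison.

The next structure is compound 4 `OC[C@H]1C[C@@H](Cn2cnc3c(-c4ccc(Cl)cc4)ncnc32)c2ccccc21`, which carries 4-chlorophenyl in place of chloro on an aromatic carbon.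

Among the compounds with values here, only one measured step bears on this change: no change at the digits printed from compound 1 to compound 2 (within the scatter). It exchanged the group on that same aromatic carbon and left the number unmoved. That step brought in no new ring, however, so it is only a weak guide to this larger exchange. No step beyond the scatter is therefore expected in this assay, and the expected step is a 1.2-fold lower number from compound 2 to compound 4 (0.08 log units; within the scatter). For compound 4 the estimated value is 20 ug/mL, with an expected range from 7 ug/mL to 55 ug/mL.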

Compound 4, half-maximal inhibitory concentration: 0.63 ug/mL
Beside the measured number, compound 4's estimate is 32-fold (1.50 log units) above it; measured number below the stated range.
By their numbers in this assay, from the lowest: compound 4; then compound 3; then compounds 1 and 2 (each within the scatter of the next).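

In this assay, this aromatic carbon proves highly responsive to the group it carries: 4-chlorophenyl in place of chloro gives a 38-fold lower number from compound 2 to compound 4 (1.58 log units; beyond the scatter), and 4-chlorophenyl in place of ethoxy gives a 38-fold lower number from compound 1 to compound 4 (1.58 log units; beyond the scatter). Within the data shown here, the exchange of ethoxy for chloro had left the number unmoved, so the earlier compounds gave no sign of this sensitivity, which appears here only with the group that brings in a six-membered aromatic ring of carbon only. Nothing measured here explains the size of this step.

The compounds shown do not separate the contribution of the new ring from that of its chlorine, since a plain phenyl group does not appear among them. They also leave open how this carbon would respond to an amine or to a ring containing nitrogen.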